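Furan-2-yl Amide Replacing the Phenyl Urea on Weakly Active Scaffold

The source may hold more compounds than are shown below. What is called first, only, known or untested is meant among the compounds shown, and "the series" means these compounds.

Compound 2 `CCOC(=O)c1csc2nc(-c3ccc(NC(=O)Nc4ccccc4)cc3)cn12` stands only at a limit in a functional assay on HeLa cells (Homo sapiens) for cytotoxicity, read by MTT assay, with a stated time of 72 h; a lower number here means a stronger inhibitor, a higher number a weaker inhibitor: compound 2 gives > 20000 nM. Its neighbour compound 1 `CCOC(=O)c1csc2nc(-c3ccc(NC(=O)Nc4ccc(Br)cn4)cc3)cn12` also gives only a limit, namely > 20000 nM. For the measured compounds named here, the single measured step, a step that the two limits leave unreadable from compound 1 to compound 2, therefore tells nothing of size, because the limit of > 20000 nM in this assay, at which 2 of the 2 values shown sit, holds both values. Compound 3 `CCOC(=O)c1csc2nc(-c3ccc(NC(=O)c4ccco4)cc3)cn12` carries furan-2-yl in place of anilino on a carbonyl carbon. Going by the values given here, no measured step bears readably on this change, so the step that the limit leaves unreadable from compound 2 to compound 3 is expected to stay unreadable, with no shift beyond scatter. Compound 3 is estimated at 30000 nM, between 8000 nM and 100000 nM.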

Compound 3, half-maximal inhibitory concentration: > 20000 nM
Compound 3: no number, only a limit; the forecaster's own chance of this, stated with the estimate: 85%; the middle value is on the limit's open side.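

No step among compound 1, compound 2 and compound 3 can be read, because each stands only at a limit: the limit of > 20000 nM in this assay, at which 3 of the 3 values shown sit.

The compounds shown leave open how strongly any of them acts in this assay, and whether furan-2-yl or anilino on the carbonyl carbon makes any difference.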